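The source may report more compounds than this note shows. Statements on the series, on what has been measured and on what is new or still open speak of the compounds shown alone.

Series notes, an ADME assay on CEM-SS cells (Homo sapiens) for cytotoxicity, read by XTT assay, with a stated time of 6 days; a higher number here means that more compound is tolerated, a lower number that less compound is tolerated:

- Compound 1 `CCCC(=O)OCSc1ccccc1C(=O)NCC(N)=O`: > 100 uM, a limit of the assay and not a number
- Compound 2 `CCCC(=O)OCSc1ccccc1C(=O)NCCCC(N)=O`: 56.6 uM
- Compound 3 `CCCC(=O)OCSc1ccccc1C(=O)NCCCCCCC(N)=O`: 10.4 uM

Compound 3 has the lowest number in the set, with 10.4 uM. The nearest measured neighbour gives a 5.4-fold lower number from compound 2 to compound 3 (0.74 log units; beyond the scatter).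

Next is compound 4 `CCCC(=O)OCSc1ccccc1C(=O)NCCCCCNC(C)=O`, with the change (acetamido in place of carbamoylmethyl on a saturated chain carbon, five bonds along the chain from an amide-type nitrogen).

Three measured steps are the nearest guide, and all of them extend the chain: an at least 1.7-fold lower number from compound 1 to compound 2 (0.24 log units; that floor lies within the scatter), an at least 9.6-fold lower number from compound 1 to compound 3 (0.98 log units; beyond the scatter) and a 5.4-fold lower number from compound 2 to compound 3 (0.74 log units; beyond the scatter). They show that this assay responds to that kind of change. The present change is different, since acetamido replaces carbamoylmethyl and the atoms stay the same. Going by the values given here, no measured step covers such a rearrangement, so the size of the step rests on an expectation alone.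

No step beyond the scatter is expected, and the number should stay close to that of compound 3 at 10.4 uM. The expected step is a 1.3-fold higher number from compound 3 to compound 4 (0.10 log units; within the scatter).

For compound 4 the estimated value is 13 uM, with an expected range of 5 uM to 35 uM.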

Compound 4, half-maximal toxic concentration: 9.2 uM
The estimate for compound 4 lay 1.4-fold (0.15 log units) above the measured number, within the range that was stated.
By their numbers in this assay, from the lowest: compounds 4 and 3 (each within the scatter of the next); then compound 2. At a limit, above all of these: compound 1.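

In this assay, the same atoms joined differently, with acetamido in place of carbamoylmethyl on a saturated chain carbon, five bonds along the chain from an amide-type nitrogen, leave no readable difference: a 1.1-fold lower number from compound 3 to compound 4 (0.05 log units; within the scatter). Compound 4 therefore keeps the separation from the shorter compounds that compound 3 already showed, with a 6.2-fold lower number from compound 2 to compound 4 (0.79 log units; beyond the scatter) and an at least 10-fold lower number from compound 1 to compound 4 (1.03 log units; beyond the scatter). The last of these steps is only a floor, since the entry for compound 1 is a limit of the assay and not a number: the limit of > 100 uM in this assay, at which 1 of the 4 values shown sits.

These compounds leave open whether the insensitivity to how the terminal atoms are joined extends to other end groups, such as an amine or a carboxylic acid. As far as these compounds go, how the number in this assay behaves with a longer chain also remains open.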